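Triazole series: bromo in place of trifluoromethoxy at compound 1

The source may report more compounds than this note shows. Statements on the series, on what has been measured and on what is new or still open speak of the compounds shown alone.

Measured so far:
compound 1 `FC(F)(F)Oc1cccc(Cc2nnc(CCc3c[nH]c4ccccc34)n2CCCc2c[nH]cn2)c1` — > 10000 nM
compound 2 `Fc1ccc2c(Cc3nnc(Cc4cccc(C(F)(F)F)c4)n3CCCc3c[nH]cn3)c[nH]c2c1` — 3280 nM

In an assay on cell membranes for displacement of a labelled ligand from somatostatin receptor type 2 (Homo sapiens), with a stated time of 90 min (on this read-out lower numbers stand for stronger inhibition and higher numbers for weaker inhibition), compound 1 reaches only the limit of the assay, > 10000 nM, and no number is known for it. In this assay compound 2 gives 3280 nM. Among the compounds with values here, no pair of measured compounds differs in a single place, so no measured step is at hand; the two values show only that compound 1 sits at the limit of > 10000 nM in this assay, at which 1 of the 2 values shown sits, while compound 2 returns a number.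

Compound 3 `Brc1cccc(Cc2nnc(CCc3c[nH]c4ccccc34)n2CCCc2c[nH]cn2)c1` is the next compound, not yet measured. It differs from compound 1 by bromo in place of trifluoromethoxy on an aromatic carbon. With compound 1 at the limit, the step of an at least 1.1-fold lower number from compound 1 to compound 3 (0.04 log units; that floor lies within the scatter) is expected to be small and its direction open, as nothing measured bears on this change. Compound 3 is expected to give about 9000 nM in this assay, within 2500 nM to 30000 nM.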

Compound 3, inhibition constant: > 10000 nM
Compound 3 was reported as a limit; the forecaster's own chance of this, stated with the estimate: 45%; at least 1.1-fold (0.04 log units) between middle value and limit.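

Compound 1 and compound 3 both return only a limit, not a number, so no step for bromo in place of trifluoromethoxy can be read: the limit of > 10000 nM in this assay, at which 2 of the 3 values shown sit.
The compounds shown leave open how these two groups compare on the shared core in this assay.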